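Cytotoxicity in MT4 cells across thiocarbamate amides

The source may report more compounds than this note shows. Statements on the series, on what has been measured and on what is new or still open speak of the compounds shown alone.

Three compounds share one core. Compound 1 `CCCCCOc1ccc(C(=O)N(C(=S)OCCN2C(=O)c3ccccc3C2=O)c2ccc(F)cc2)cc1` sits at a limit of an ADME assay on MT4 cells (Homo sapiens) for cytotoxicity, read by MTT assay (on this read-out higher numbers stand for lower toxicity in this test and lower numbers for higher toxicity in this test), giving > 100000 nM (the limit of > 100000 nM in this assay, at which 1 of the 3 values shown sits). Compound 3 `Cc1ccc(N(C(=O)c2ccc(Cl)c([N+](=O)[O-])c2)C(=S)OCCN2C(=O)c3ccccc3C2=O)cc1` gives 47000 nM in this assay. Compound 2 `O=C1c2ccccc2C(=O)N1CCOC(=S)N(C(=O)c1cccc([N+](=O)[O-])c1)c1ccc(Cl)cc1` gives 18000 nM, the lowest of the two numbers, and its gap to compound 3 lies beyond the scatter. Compound 4 `O=C1c2ccccc2C(=O)N1CCOC(=S)N(C(=O)c1cc2ccccc2s1)c1ccc(Cl)cc1` has not yet been measured in this assay; it differs from compound 2 by 1-benzothiophen-2-yl in place of 3-nitrophenyl on a carbonyl carbon, the change sitting on a carbonyl carbon whose other neighbour is an amide-type nitrogen. Going by the values given here, no measured pair shows this change, so the size of the step is open. For compound 4 a modest rise is expected, the step from compound 2 being a 1.7-fold higher number from compound 2 to compound 4 (0.22 log units; within the scatter). Compound 4 is therefore estimated at 30000 nM, within 8000 nM to 100000 nM.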

Compound 4, half-maximal cytotoxic concentration: 56000 nM
Compound 4: middle estimate off by 1.9-fold (0.27 log units), on the low side; measured number inside the range.
By their numbers in this assay, from the lowest: compound 2; then compounds 3 and 4 (each within the scatter of the next). At a limit, above all of these: compound 1.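

In this assay, going by these compounds alone, the step of a 3.1-fold higher number from compound 2 to compound 4 (0.49 log units; beyond the scatter) is the first measured change at this position, and it lies beyond the scatter. A change on this carbonyl carbon alone, with 1-benzothiophen-2-yl in place of 3-nitrophenyl, is thus enough to give a higher number, which stands for lower toxicity in this test. Nothing measured here bears on the cause of this step. On these data alone, how a plain phenyl, a pyridine or a benzoic acid group would compare on this carbonyl carbon stays open. Also open, as far as these compounds go, is whether the same change gives a similar step with another group on the amide-type nitrogen.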